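A few compounds are considered here, and "the series" means these few. Any claim that something is new, unique, unknown or untested is made for them only; others in the source may bear on it.

Compound 3 `Fc1ccc(COc2cccc(-c3cn(C4CN5CCC4CC5)nn3)c2)cc1` gives 1010 nM in an assay on HEK293 cells for displacement of a labelled ligand from Neuronal acetylcholine receptor; alpha4/beta2 (Homo sapiens), read by scintillation counting, with a stated time of 120 min (a lower number here means a stronger inhibitor, a higher number a weaker inhibitor), the highest of the three numbers measured. Within the data shown here, compound 2 `Fc1cccc(-c2cn(C3CN4CCC3CC4)nn2)c1` gives 748 nM, and the only single-point step measured, a 1.4-fold higher number from compound 2 to compound 3 (0.13 log units; within the scatter), lies within the scatter. Compound 1 `c1ccc(COc2cccc(-c3cn([C@@H]4CN5CCC4CC5)nn3)c2)cc1` gives 414 nM, and the gap between compound 1 and compound 3 is beyond the scatter.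

Compound 4 `c1ccc(COc2cccc(-c3cn(C4CN5CCC4CC5)nn3)c2)cc1` differs from compound 3 by hydrogen in place of fluoro on an aromatic carbon, the fluoro sitting para to a large group. Among the measured compounds shown here, no measured step exchanges fluoro for hydrogen, so the single step measured does not bear on this change directly. Compound 4 is, however, the same structure as compound 1 apart from the unspecified configuration of the bicyclic amine carbon, and compound 1 gives 414 nM. On that basis compound 4 is expected to fall near the number of compound 1, an estimated step of a 2.2-fold lower number from compound 3 to compound 4 (0.35 log units; beyond the scatter) toward a lower number. The estimate for compound 4 in this assay is therefore 450 nM, with a range from 200 nM to 1000 nM.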

Compound 4, inhibition constant: 668 nM
The estimate for compound 4 lay 1.5-fold (0.17 log units) below the measured number; the range from low to high includes it.
By their numbers in this assay, from the lowest: compounds 1, 4, 2 and 3 (each within the scatter of the next, the first and the last beyond it).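

In this assay, hydrogen in place of fluoro on the aromatic carbon para to a large group gives a 1.5-fold lower number from compound 3 to compound 4 (0.18 log units; within the scatter), so among these compounds the exchange at this position stays within the scatter. Benzyloxy in place of fluoro gives a 1.1-fold lower number from compound 2 to compound 4 (0.05 log units; within the scatter), which is also within the scatter and matches the earlier result for the (4-fluorobenzyl)oxy group, so neither form of the larger group separates from compound 2. The step to the undefined drawing, a 1.6-fold higher number from compound 1 to compound 4 (0.21 log units; within the scatter), likewise stays within the scatter and involves no change in atoms or bonds: the fact that one of compounds 1 and 4 is drawn with a defined configuration and the other without, at the place where they differ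

The compounds shown leave open whether chloro, methoxy or an amine at the place of the fluoro would move the number beyond the scatter. They also leave open how the opposite configuration at the saturated ring carbon would read.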